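This account rests on a few compounds, and the source may have more. Where it says the series, first, only, none or still open, it means among the compounds named here.

Measured compounds:

- compound 1 `CC1(C)CC(NC(=S)Nc2ccc(C#N)cc2)c2cc(Cl)ccc2O1`: 10000 nM
- compound 2 `CC1(C)CC(NC(=S)Nc2ccc([N+](=O)[O-])cc2)c2cc(Cl)ccc2O1`: 3000 nM
- compound 3 `CC1(C)CC(NC(=S)Nc2cccc([N+](=O)[O-])c2)c2cc(Cl)ccc2O1`: 3000 nM

All three numbers come from a functional assay on U-373MG ATCC cells (Homo sapiens) for inhibition, read by MTT assay, with a stated time of 72 h (on this read-out lower numbers stand for stronger inhibition and higher numbers for weaker inhibition), and were read at the stated time. Compound 2 and compound 3 share the same atoms joined differently; the difference between their two cores is not broken down here. In this assay compound 3 stands level with compound 2 at the digits given, so no order between the two is claimed.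

One change is recorded with its step: cyano in place of nitro on an aromatic carbon, which gave a 3.3-fold higher number from compound 2 to compound 1 (0.52 log units; beyond the scatter). Among the measured compounds shown here, this single step is the only measured guide for the same kind of change elsewhere.

Compound 4 `CC1(C)CC(NC(=S)Nc2cccc(C#N)c2)c2cc(Cl)ccc2O1` has not yet been measured in this assay. It differs from compound 3 by cyano in place of nitro on an aromatic carbon. For the measured compounds named here, this is the same kind of change as the one from compound 2 to compound 1, but not the same change: in the measured pair the group sits para to a large group, whereas in compound 4 it sits meta to a large group. Going by the values given here, with only one measured instance, the expectation for compound 4 rests on that instance alone, and a step of about a 3.0-fold higher number from compound 3 to compound 4 (0.48 log units; beyond the scatter) is expected because compound 1 showed a 3.3-fold higher number from compound 2 to compound 1 (0.52 log units; beyond the scatter) after the same kind of change. For compound 4 in this assay the estimate is 9000 nM, expected to lie between 3000 nM and 25000 nM.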

Compound 4, half-maximal inhibitory concentration: 7000 nM
For compound 4 the middle estimate is 1.3-fold (0.11 log units) above the measured one, and the stated range covers the measured number.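

In this assay, cyano in place of nitro on an aromatic carbon, here meta to a large group, gave a 2.3-fold higher number from compound 3 to compound 4 (0.37 log units; beyond the scatter), and the change can now be compared across two cores: the same change on two cores in this assay, a 3.3-fold higher number (0.52 log units; beyond the scatter) from compound 2 to compound 1 and a 2.3-fold higher number (0.37 log units; beyond the scatter) from compound 3 to compound 4, 1.4-fold (0.15 log units) apart, within the scatter of two such steps. Within these two pairs, the change therefore carries from one core to the other in direction and, within the scatter, in size, so the earlier step was a usable guide for compound 4. This does not show that the change would carry to other ring places or to cores altered elsewhere, as two pairs on one aromatic ring form a narrow base, and 3-cyanophenyl in place of 4-cyanophenyl gave a 1.4-fold lower number from compound 1 to compound 4 (0.15 log units; within the scatter), so no order between those two compounds is claimed.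

The compounds shown leave open what an amine or a carboxylic acid would give on the same aromatic ring in place of cyano or nitro. They also leave open whether the step from nitro to cyano would persist with bromo in place of the chloro group on the shared core, or with oxygen in place of the sulfur of the linker.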